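Extending the piperazine substituent of an aryl sulfone benzoxazole

The source may hold more compounds than are shown below. What is called first, only, known or untested is meant among the compounds shown, and "the series" means these compounds.

Of the compounds shown here, three sharing one core have been measured in an assay on HeLa cells for displacement of a labelled ligand from 5-hydroxytryptamine receptor 6 (Homo sapiens); on this read-out higher numbers stand for weaker inhibition and lower numbers for stronger inhibition. Compound 1 `O=S(=O)(c1cccc(F)c1)c1cccc2oc(N3CCNCC3)nc12` gives 54 nM. Compound 2 `COc1cccc(S(=O)(=O)c2cccc3oc(N4CCNCC4)nc23)c1`, which differs only by a methoxy in place of fluoro on an aromatic carbon, gives 25 nM; this is a 2.2-fold lower number from compound 1 to compound 2 (0.33 log units; beyond the scatter). Compound 3 `CN1CCN(c2nc3c(S(=O)(=O)c4cccc5ccccc45)cccc3o2)CC1`, carrying a naphthyl sulfone and a methyl on the piperazine nitrogen, gives 9.7 nM, the lowest of the three numbers, beyond the scatter from compound 2 and further still from compound 1.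

Compound 4 `CC(C)CN1CCN(c2nc3c(S(=O)(=O)c4cccc5ccccc45)cccc3o2)CC1` has not yet been measured. The change from compound 3 is isopropyl in place of hydrogen on a saturated chain carbon bound to an amine nitrogen in a ring, so the methyl on the piperazine becomes an isobutyl. For the measured compounds named here, no measured step touches this part of the molecule: the only measured step, from compound 1 to compound 2, alters a substituent on the sulfone aryl ring, not the piperazine chain. Going by the values given here, there is thus no direct precedent for the size or direction of the effect. The expected step is a 1.2-fold higher number from compound 3 to compound 4 (0.09 log units; within the scatter), that is, nothing clearly beyond the scatter. Compound 4 is therefore estimated at 12 nM in this assay, with a range from 4 nM to 40 nM.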

Compound 4, inhibition constant: 176 nM
Beside the measured number, compound 4's estimate is 15-fold (1.17 log units) below it; the measured number lies above the stated range.
By their numbers in this assay, from the lowest: compound 3; then compound 2; then compound 1; then compound 4.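

On the piperazine nitrogen, exchanging methyl for isobutyl gives an 18-fold higher number from compound 3 to compound 4 (1.26 log units; beyond the scatter) in this assay and so means weaker inhibition, the first measured sign that this site does not accept every alkyl group equally. The change is only the isopropyl that replaces a hydrogen on a saturated chain carbon bound to an amine nitrogen in a ring, with 3 carbon atoms, no ring and no hydrogen-bond donors or acceptors, yet this step is larger than a 2.2-fold lower number from compound 1 to compound 2 (0.33 log units; beyond the scatter) seen on the sulfone aryl ring, so the piperazine substituent can matter at least as much as that aryl substituent in this series. Nothing measured here explains why this particular change weakens inhibition so strongly.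

With only methyl and isobutyl compared on this naphthyl sulfone, the compounds shown cannot separate the effect of chain length from that of branching, which an ethyl group or a straight butyl chain would help to do. They also leave open how the hydrogen found on the piperazine of compound 1 and compound 2 would compare with methyl on the naphthyl sulfone, and whether a chain ending in a hydroxyl or an amine would fare differently from isobutyl.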